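Phenylethyl amide variant in the guanidinobenzoyl series

A few compounds are considered here, and "the series" means these few. Any claim that something is new, unique, unknown or untested is made for them only; others in the source may bear on it.

Going by the values given here, compound 1 `N=C(N)Nc1cccc(C(=O)NCC(=O)N[C@@H](CC(=O)O)C(=O)Nc2ccccc2)c1` gives 13 nM in an assay on a protein complex for binding affinity to integrin alpha-5/beta-1 (Homo sapiens), read by ELISA, with a stated time of 1 h (a higher number here means a weaker inhibitor, a lower number a stronger inhibitor), the lowest of the two numbers measured so far. Compound 2 `N=C(N)Nc1cccc(C(=O)NCC(=O)N[C@@H](CC(=O)O)C(=O)NCc2ccccc2)c1` gives 31 nM, and the step of a 2.4-fold higher number from compound 1 to compound 2 (0.38 log units; beyond the scatter) is modest but beyond the scatter. Compound 3 `C[C@H](NC(=O)[C@H](CC(=O)O)NC(=O)CNC(=O)c1cccc(NC(=N)N)c1)c1ccccc1` carries the change (1-phenylethyl in place of phenyl on an amide-type nitrogen), which resembles the change seen in compound 2, so that step is the one that bears on it. A weakening of similar size is expected, a 2.7-fold higher number from compound 1 to compound 3 (0.43 log units; beyond the scatter). Compound 3 is therefore estimated at 35 nM, with a range from 15 nM to 90 nM.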

Compound 3, half-maximal inhibitory concentration: 20 nM
The estimate for compound 3 lay 1.8-fold (0.24 log units) above the measured number; low and high end bracket the measured number.
By their numbers in this assay, from the lowest: compounds 1, 3 and 2 (each within the scatter of the next, the first and the last beyond it).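

In this assay, 1-phenylethyl on the amide-type nitrogen reads level with phenyl (a 1.5-fold higher number from compound 1 to compound 3 (0.19 log units; within the scatter)), so this position accepts the larger group without a step beyond the scatter. Methyl in place of hydrogen on the saturated chain carbon also leaves the reading level (a 1.6-fold lower number from compound 2 to compound 3 (0.19 log units; within the scatter)), and the gap between phenyl and benzyl does not carry over to 1-phenylethyl. No measured evidence bears on the cause of these readings.

Open, from the compounds shown here alone, is how the opposite stereocentre of 1-phenylethyl would read, and how a longer chain such as 2-phenylethyl or a carboxylic acid on the phenyl ring would read.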